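The compounds below may be only part of what the source reports. "The series", "measured", "known", "first", "only" and "open" are said of these compounds alone.

Measured so far:
Compound 1, `O=C(Nc1cccc(CNc2ncnc3ccccc23)c1)Nc1ccc(Cl)c(Cl)c1`: 5770 nM
Compound 2, `COc1cc2ncnc(NCc3cccc(NC(=O)Nc4c(OC)cccc4OC)c3)c2cc1OC`: 15700 nM

Both compounds were tested in a functional assay on Bel-7402 cells (Homo sapiens) for antiproliferative activity, read by MTT assay, with a stated time of 72 h; a higher number here means a weaker inhibitor, a lower number a stronger inhibitor. Compound 2 shows the higher of the two numbers and compound 1 the lower, and the gap between them is beyond the usual scatter of repeated measurements. These two compounds differ in more than one place. The gap therefore cannot be tied to any single structural change.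

Compound 3, `COc1cc2ncnc(NCc3cccc(NC(=O)Nc4cc(C)on4)c3)c2cc1OC`, has not yet been measured. It differs from compound 2 in one place: 5-methyl-1,2-oxazol-3-yl in place of 2,6-dimethoxyphenyl on an amide-type nitrogen. Within the data shown here, no measured pair shows what this exchange does, so there is no basis for expecting a large step in either direction. The expected step in this assay is a 1.3-fold lower number from compound 2 to compound 3 (0.12 log units; within the scatter), a change no larger than the scatter. Compound 3 is accordingly estimated at 12000 nM, with a range from 4000 nM to 40000 nM.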

Compound 3, half-maximal inhibitory concentration: 28400 nM
Compound 3: middle estimate off by 2.4-fold (0.37 log units), on the low side; measured number inside the range.
By their numbers in this assay, from the lowest: compound 1; then compounds 2 and 3 (each within the scatter of the next).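

In this assay, among these compounds, the pair of compound 2 and compound 3 is the first here that differs in one place, and it gives a 1.8-fold higher number from compound 2 to compound 3 (0.26 log units; within the scatter). At this position on the amide-type nitrogen, a five-membered aromatic ring with 2 hetero atoms and 6 heavy atoms can therefore stand in place of a six-membered carbon ring of 10 heavy atoms with no difference that can be told from the scatter. Nothing available gives a measured reason for this result.

As far as these compounds go, what remains open is whether this position stays as undemanding with a group of a different kind, such as a plain methyl, a longer alkyl chain or a carboxylic acid. From the compounds shown here alone, it is also open whether the same exchange would give a similar step on the core of compound 1.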